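The source may report more compounds than this note shows. Statements on the series, on what has been measured and on what is new or still open speak of the compounds shown alone.

In an ADME assay on microsomes from liver (Homo sapiens) for metabolic stability, read by LC-MS, with a stated time of 10 min, tested at 0.5 uM (on this read-out higher numbers stand for a more stable compound and lower numbers for a less stable compound), compound 3 (`CCN1CCN(CCCN(C[C@H]2Cc3ccccc3CN2)[C@H]2CCCc3cccnc32)CC1`) gives 59%. Compound 1 (`c1ccc2c(c1)CN[C@@H](CN(CCC1CCNCC1)[C@H]1CCCc3cccnc31)C2`) gives 66%, which lies within the scatter of compound 3, while compound 2 (`CC(C)N1CCN(CCCN(C[C@H]2Cc3ccccc3CN2)[C@H]2CCCc3cccnc32)CC1`) gives 46%, beyond the scatter of compound 3.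

Compound 4 (`c1ccc2c(c1)CN[C@@H](CN(CCN1CCNCC1)[C@H]1CCCc3cccnc31)C2`) differs from compound 3 by piperazin-1-yl in place of (4-ethylpiperazin-1-yl)methyl on a saturated chain carbon, two bonds along the chain from an amine nitrogen, on a saturated chain carbon, two bonds along the chain from an amine nitrogen. The same difference also reads as 3-(4-ethylpiperazin-1-yl)propyl to 2-(piperazin-1-yl)ethyl.

Going by the values given here, no measured step makes this exact change, so the evidence is indirect. Like compound 1, compound 4 has no ethyl or isopropyl group on its ring, and a number 7 percentage points lower from compound 1 to compound 3 (within the scatter) stays within the scatter. The other two steps are modest: a number 20 percentage points lower from compound 1 to compound 2 (beyond the scatter) and a number 13 percentage points higher from compound 2 to compound 3 (beyond the scatter). A step within the scatter is therefore expected, upward if it shows at all. The expected step is a number 7 percentage points higher from compound 3 to compound 4 (within the scatter). For compound 4 the estimated value is 66%, with an expected range of 50% to 80%.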

Compound 4, percent of the compound remaining: 96%
Compound 4: the middle estimate sits 30 percentage points below what was measured; the whole stated range lies below it.
By their numbers in this assay, from the lowest: compound 2; then compounds 3 and 1 (each within the scatter of the next); then compound 4.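

In this assay, piperazin-1-yl on a saturated chain carbon, two bonds along the chain from an amine nitrogen, gives a large gain over both alkylated piperazines: a number 37 percentage points higher from compound 3 to compound 4 (beyond the scatter) and a number 50 percentage points higher from compound 2 to compound 4 (beyond the scatter). Compound 1 also has no ethyl or isopropyl group on its ring, yet the read-out is a number 30 percentage points higher from compound 1 to compound 4 (beyond the scatter), so the absence of such a group is not enough to reach the level of compound 4. Nothing shown here gives a reason for this gain.

The step from compound 3 to compound 4 changes both the chain and the ethyl group, and these compounds do not separate the two. A 3-(piperazin-1-yl)propyl or 2-(4-ethylpiperazin-1-yl)ethyl group would test each alone, while a 2-(morpholin-4-yl)ethyl group would test whether the second ring nitrogen is needed.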